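The compounds below may be only part of what the source reports. "The series", "measured", "known", "first", "only" and "open" are said of these compounds alone.

Three compounds have been measured in a functional assay on SW 1116 cells (Homo sapiens) for cytotoxicity, read by MTT assay, with a stated time of 48 h; a higher number here means a weaker inhibitor, a lower number a stronger inhibitor:

compound 1, `O=C(CSc1nnc(-c2ccncc2)o1)N/N=C/c1ccc(F)cc1`, gives 15700 nM
compound 2, `O=C(CSc1nnc(-c2ccncc2)o1)N/N=C/c1ccc(Cl)cc1`, gives 17000 nM
compound 3, `O=C(CSc1nnc(-c2ccncc2)o1)N/N=C/c1ccc([N+](=O)[O-])cc1`, gives 25800 nM

Compound 3 carries the highest of the three numbers, but the steps of a 1.5-fold higher number from compound 2 to compound 3 (0.18 log units; within the scatter) and a 1.6-fold higher number from compound 1 to compound 3 (0.22 log units; within the scatter) both lie within the scatter, so the three compounds are not told apart by this assay.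

Compound 4, `O=C(CSc1nnc(-c2ccncc2)o1)N/N=C/c1ccc(O)cc1`, differs from compound 3 by hydroxy in place of nitro on an aromatic carbon. Within the data shown here, the only steps available are swaps at that same position: a 1.1-fold higher number from compound 1 to compound 2 (0.03 log units; within the scatter), a 1.6-fold higher number from compound 1 to compound 3 (0.22 log units; within the scatter) and a 1.5-fold higher number from compound 2 to compound 3 (0.18 log units; within the scatter), none reaching beyond the scatter. A hydroxy has not been tested at this place, so the expectation rests on those three flat steps alone: for compound 4 a step of a 1.3-fold lower number from compound 3 to compound 4 (0.11 log units; within the scatter) is expected, not beyond the scatter. Compound 4 is therefore estimated at 20000 nM, within 8000 nM to 50000 nM.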

Compound 4, half-maximal inhibitory concentration: 12200 nM
Compound 4: the middle estimate sits 1.6-fold (0.21 log units) above what was measured, within the range that was stated.
By their numbers in this assay, from the lowest: compounds 4, 1, 2 and 3 (each within the scatter of the next, the first and the last beyond it).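

In this assay, this position gives its first step beyond the scatter: hydroxy in place of nitro produces a modest change (a 2.1-fold lower number from compound 3 to compound 4 (0.33 log units; beyond the scatter)). Hydroxy is not told apart from chloro (a 1.4-fold lower number from compound 2 to compound 4 (0.14 log units; within the scatter)) or fluoro (a 1.3-fold lower number from compound 1 to compound 4 (0.11 log units; within the scatter)), so only the nitro and hydroxy compounds are separated. No available evidence explains this difference.

On these data alone, whether an amine, a carboxylic acid or a methoxy at this place would give a larger step remains open. So does whether the same swap would behave alike on a changed core.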